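Urea series in the cell inhibition assay: note on compound 3

A few compounds are considered here, and "the series" means these few. Any claim that something is new, unique, unknown or untested is made for them only; others in the source may bear on it.

Measured so far:
compound 1 `COc1ccc(OC)c(Nc2cc(NC(=O)Nc3c(Cl)cccc3Cl)ncn2)c1` gives 74%
compound 2 `COc1ccc(C(F)(F)F)cc1Nc1cc(NC(=O)Nc2c(Cl)cccc2Cl)ncn1` gives 33%

Both values come from a functional assay on NCI-H520 cells (Homo sapiens) for inhibition, read by MTT assay, with a stated time of 48 h, tested at 10 uM; a lower number here means less inhibition, a higher number more inhibition at the concentration tested (going by the name of the read-out). Going by the values given here, the one measured step is a number 41 percentage points lower from compound 1 to compound 2 (beyond the scatter). On these two numbers compound 2 stands lowest, and its nearest neighbour is compound 1, which in this assay gives a number higher by a margin beyond the scatter.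

Compound 3 `COc1cc(NC(=O)Nc2cc(Nc3cc(C(F)(F)F)ccc3OC)ncn2)cc(OC)c1` has not yet been measured in this assay. It differs from compound 2 in one place: 3,5-dimethoxyphenyl in place of 2,6-dichlorophenyl on an amide-type nitrogen. Among the compounds with values here, the only measured step, from compound 1 to compound 2, concerns a different position and a different pair of groups, so no measured step bears on this change. There is therefore no basis in the shown numbers for expecting a step in either direction, and the working expectation is a step of no clear size beyond the scatter, namely a number 2 percentage points higher from compound 2 to compound 3 (within the scatter). The estimate for compound 3 in this assay is 35%, with a wide range from 10% to 65% reflecting the absence of any comparable step.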

Compound 3, a percentage reported as inhibition, at one concentration (the size of the read-out at that concentration, not a potency): 63%
The estimate for compound 3 lay 28 percentage points below the measured number; measured number inside the range.
By their numbers in this assay, from the lowest: compound 2; then compound 3; then compound 1.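

In this assay, 3,5-dimethoxyphenyl in place of 2,6-dichlorophenyl on an amide-type nitrogen gives a number 30 percentage points higher from compound 2 to compound 3 (beyond the scatter), the first measured sign that the group at this place moves the read-out. Going by these compounds alone, earlier, the only measured change was trifluoromethyl in place of methoxy on an aromatic carbon; compound 2 and compound 3 both keep the trifluoromethyl group, so its presence does not by itself fix the number at the low level seen for compound 2. No measurement at hand speaks to what lies behind this step.

Within the data shown here, the single step exchanges two chlorine atoms for two methoxy groups and 2,6-substitution for 3,5-substitution at once, so it remains open whether the higher number follows the methoxy groups, the loss of the chlorine atoms, or the change from one substitution pattern to the other. Also open, going by these compounds, are how this place responds to a plain phenyl or to a phenyl carrying a morpholine or a carboxylic acid, and whether the same exchange gives a step of similar direction that carries methoxy in place of trifluoromethyl.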